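Changing the ring-nitrogen substituent: expectations for compound 3

This account rests on a few compounds, and the source may have more. Where it says the series, first, only, none or still open, it means among the compounds named here.

compound 1 `C=CS(=O)(=O)N1CCN(c2ncnc3sc(-c4ccc(OC)nc4)cc23)CC1`: 11900 nM
compound 2 `CN1CCN(c2ccc(-c3cc4c(N5CCN(S(=O)(=O)N6CCCCC6)CC5)ncnc4s3)cc2)CC1`: 7570 nM

In a functional assay on MDA-MB-436 cells (Homo sapiens) for antiproliferative activity, read by MTT assay, with a stated time of 48 h (on this read-out higher numbers stand for weaker inhibition and lower numbers for stronger inhibition), compound 2 gives 7570 nM and compound 1 gives 11900 nM; compound 2 holds the smaller of the two numbers, but compound 1 sits within the scatter of it, so the two are not separated. Compound 3 `CN1CCN(c2ccc(-c3cc4c(N5CCN(C(=O)Nc6ccc(F)cc6F)CC5)ncnc4s3)cc2)CC1` remains to be measured. It differs from compound 2 in one place: (2,4-difluorophenyl)carbamoyl in place of (piperidin-1-yl)sulfonyl on an amine nitrogen in a ring. Among the measured compounds shown here, no measured pair isolates this change. The step of a 1.5-fold lower number from compound 2 to compound 3 (0.18 log units; within the scatter) is expected to be small, toward stronger inhibition, and not clearly beyond the scatter. Compound 3 is estimated at 5000 nM in this assay, with a range from 1500 nM to 16000 nM.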

Compound 3, half-maximal inhibitory concentration: 20200 nM
The estimate for compound 3 lay 4.0-fold (0.61 log units) below the measured number; the measured number lies above the stated range.
By their numbers in this assay, from the lowest: compounds 2, 1 and 3 (each within the scatter of the next, the first and the last beyond it).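

In this assay, (2,4-difluorophenyl)carbamoyl in place of (piperidin-1-yl)sulfonyl on an amine nitrogen in a ring gives a 2.7-fold higher number from compound 2 to compound 3 (0.43 log units; beyond the scatter), so this position does respond to its substituent, and this exchange goes toward weaker inhibition. Nothing available shows which part of the exchange carries the step. The compounds shown leave open whether the loss follows the carbamoyl link or the two fluorines. An unsubstituted phenylcarbamoyl, or a methanesulfonyl or acetyl on the same nitrogen, would help separate these.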